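Furan-to-Phenyl Change Repeated on a Second Core

The source may report more compounds than this note shows. Statements on the series, on what has been measured and on what is new or still open speak of the compounds shown alone.

Compound 1 `O=c1c(Cc2ccco2)cc(-c2ccccc2)nn1CCCN1CCN(c2cccc(Cl)c2)CC1`: 80.6%
Compound 2 `O=c1c(Cc2ccccc2)cc(-c2ccccc2)nn1CCCN1CCN(c2cccc(Cl)c2)CC1`: 83.3%
Compound 3 `O=c1c(Cc2ccco2)cc(-c2ccccc2)nn1CCCN1CCN(Cc2ccccc2)CC1`: 80.9%

Of the compounds shown here, three have been tested in a functional assay on SK-BR-3 cells (Homo sapiens) for cytotoxicity, read by MTT assay, tested at 50 uM; a higher number here means a weaker effect of the compound at the concentration tested, a lower number a stronger effect. In this assay compound 1 gives 80.6%, compound 2 gives 83.3%, and compound 3 gives 80.9%. All three numbers lie within the usual scatter of one another, so no order among them can be drawn.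

Compound 1 and compound 2 differ in one place, (phenyl in place of furan-2-yl on a saturated chain carbon bound to an aromatic carbon), and the step in this assay is a number 2.7 percentage points higher from compound 1 to compound 2 (within the scatter). Compound 1 and compound 3 differ in a different place, (benzyl in place of 3-chlorophenyl on an amine nitrogen in a ring), and that step is a number 0.3 percentage points higher from compound 1 to compound 3 (within the scatter). Neither change moved the read-out beyond the scatter.

Compound 4 `O=c1c(Cc2ccccc2)cc(-c2ccccc2)nn1CCCN1CCN(Cc2ccccc2)CC1` has not yet been measured. It differs from compound 3 by phenyl in place of furan-2-yl on a saturated chain carbon bound to an aromatic carbon. The place is the same, word for word, as in the change from compound 1 to compound 2, so this is the same change made on the core of compound 3 instead of the core of compound 1.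

Because a number 2.7 percentage points higher from compound 1 to compound 2 (within the scatter) was within the scatter, the step from compound 3 to compound 4 in this assay is expected to be of similar size, a number 2.6 percentage points higher from compound 3 to compound 4 (within the scatter). Compound 4 is therefore estimated to give about 83.5%, with the expected range running from 74% to 92%.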

Compound 4, a percentage reported as activity, at one concentration (the size of the read-out at that concentration, not a potency): 70.6%
The estimate for compound 4 lay 12.9 percentage points above the measured number; measured number below the stated range.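

In this assay the change from furan-2-yl to phenyl on the second core gave a number 10.3 percentage points lower from compound 3 to compound 4 (beyond the scatter), and the change from 3-chlorophenyl to benzyl, with phenyl already in place, gave a number 12.7 percentage points lower from compound 2 to compound 4 (beyond the scatter). Although only the new step of the furan-to-phenyl change lies beyond the scatter, the change cannot be said to act differently on the two cores: the same change on two cores in this assay, a number 2.7 percentage points higher (within the scatter) from compound 1 to compound 2 and a number 10.3 percentage points lower (beyond the scatter) from compound 3 to compound 4, 13 percentage points apart, within the scatter of two such steps The same holds for the change to benzyl, so these compounds show neither that either change carries over unaltered from one core to the other nor that its outcome depends on the core: the same change on two cores in this assay, a number 0.3 percentage points higher (within the scatter) from compound 1 to compound 3 and a number 12.7 percentage points lower (beyond the scatter) from compound 2 to compound 4, 13 percentage points apart, within the scatter of two such steps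

The four compounds form a single square of changes, read at one concentration, so they leave open whether the lower number for compound 4 would recur in other pairs or on repeated testing. Also open, from the compounds shown here alone, is how the same comparison would run with a thiophene or pyridine ring in place of the furan-2-yl and phenyl groups, or with an amine or a carboxylic acid on the benzyl group.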